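The compounds below may be only part of what the source reports. "The series", "measured", "known", "first", "only" and "open" are said of these compounds alone.

Measured compounds:
- compound 1 `CC1=NC(C)=C(C(=O)O)C(c2ccc([N+](=O)[O-])cc2)/C1=C(\O)OC/C=C/c1ccccc1`: 1600 nM
- compound 2 `CC1=NC(C)=C(C(=O)O)C(c2cccc(C)c2)/C1=C(\O)OC/C=C/c1ccccc1`: 76 nM

In a functional assay on thoracic aorta for inhibition of Voltage-gated L-type calcium channel (Rattus norvegicus) (on this read-out lower numbers stand for stronger inhibition and higher numbers for weaker inhibition), compound 1 gives 1600 nM, the higher of the two numbers measured, and in the same assay compound 2 gives 76 nM. Within the data shown here, the one step between them is a 21-fold lower number from compound 1 to compound 2 (1.32 log units; beyond the scatter). Compound 3 `CC1=NC(C)=C(C(=O)O)C(c2cccc(Cl)c2)/C1=C(\O)OC/C=C/c1ccccc1` has not yet been measured in this assay. From compound 1 to compound 3 the change is 3-chlorophenyl in place of 4-nitrophenyl on a saturated ring carbon. Among the measured compounds shown here, the only measured step that bears on this change is a 21-fold lower number from compound 1 to compound 2 (1.32 log units; beyond the scatter), where a different group also replaced the 4-nitrophenyl on the same saturated ring carbon and the number fell by a large amount. Compound 3 is therefore expected to show a step of similar direction and size, an 18-fold lower number from compound 1 to compound 3 (1.25 log units; beyond the scatter), since the group entering in compound 2 gave 76 nM. The estimate for compound 3 in this assay is 90 nM, with a range from 20 nM to 400 nM.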

Compound 3, half-maximal inhibitory concentration: 20 nM
Compound 3: middle estimate off by 4.5-fold (0.65 log units), on the high side, and the stated range covers the measured number.
By their numbers in this assay, from the lowest: compound 3; then compound 2; then compound 1.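

In this assay, the large fall seen with 3-methylphenyl recurs when 3-chlorophenyl enters on the saturated ring carbon, with an 80-fold lower number from compound 1 to compound 3 (1.90 log units; beyond the scatter), so that fall is not confined to one incoming group. The two groups are also not interchangeable: chloro in place of methyl on an aromatic carbon gives a 3.8-fold lower number from compound 2 to compound 3 (0.58 log units; beyond the scatter), a modest step, but one that shows the number still responds to this single aromatic substituent. No measurement available here explains either step.

Going by these compounds, how a 3-nitrophenyl or a 4-chlorophenyl group would behave on this carbon remains open, and with it whether the large steps from compound 1 follow the nitro group or its place on the aromatic ring. Also open, on these data alone, is where an unsubstituted phenyl or a 3-methoxyphenyl group would fall relative to compound 2 and compound 3.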